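The source may report more compounds than this note shows. Statements on the series, on what has been measured and on what is new or still open speak of the compounds shown alone.

For the measured compounds named here, in a functional assay on MT4 cells (Homo sapiens) for cytotoxicity, read by CellTiter-Glo, with a stated time of 5 days (a higher number here means that more compound is needed for the effect, a lower number that less compound is needed), compound 1 `Cc1ccc(-c2c(C)noc2C)cc1S(=O)(=O)NC1CCCC1` gives 1590 nM and stands highest of the two numbers so far. Compound 2 `Cc1noc(C)c1-c1cc(-c2c(C)noc2C)c2nc(C3CC3)[nH]c2c1` gives 80 nM by comparison, a gap beyond the usual scatter. Compound 3 `Cc1cc(-c2ccc(C)c(S(=O)(=O)NC3CCCC3)c2)cnn1` carries 6-methylpyridazin-4-yl in place of 3,5-dimethyl-1,2-oxazol-4-yl on an aromatic carbon of compound 1 6-methylpyridazin-4-yl in place of 3,5-dimethyl-1,2-oxazol-4-yl on an aromatic carbon and is otherwise unchanged. Going by the values given here, no measured pair shows such a swap, so the expectation is loose: a modest rise in this assay that may stay within the scatter. The expected change is a 1.6-fold higher number from compound 1 to compound 3 (0.20 log units; within the scatter) and remains a rough guess. Compound 3 is estimated at 2500 nM with an expected range from 700 nM to 9000 nM in this measurement.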

Compound 3, half-maximal effective concentration: 3760 nM
The estimate for compound 3 lay 1.5-fold (0.18 log units) below the measured number; the range from low to high includes it.
By their numbers in this assay, from the lowest: compound 2; then compound 1; then compound 3.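

In this assay, 6-methylpyridazin-4-yl in place of 3,5-dimethyl-1,2-oxazol-4-yl gives a 2.4-fold higher number from compound 1 to compound 3 (0.37 log units; beyond the scatter), a modest step showing that this aromatic carbon, para to the methyl group, responds to the choice of ring. The two groups match in heavy atoms, hydrogen-bond donors and hydrogen-bond acceptors, so these counts alone do not separate them. No measurement shown explains the step. On these data alone, how a plain phenyl ring or an amine would read at this carbon stays open, as does whether the same swap would move the number similarly on another core.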